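A few compounds are considered here, and "the series" means these few. Any claim that something is new, unique, unknown or untested is made for them only; others in the source may bear on it.

Measured in an ADME assay on HaCaT cells (Homo sapiens) for antiproliferative activity, with a stated time of 48 h (on this read-out lower numbers stand for stronger inhibition and higher numbers for weaker inhibition), where each value is a limit of the assay:
Compound 1 `CCN(CC)c1ccc(-c2cccc(OC)c2)nn1`: > 25000 nM
Compound 2 `CCN(CC)c1ccc(-c2cccc(C#N)c2)nn1`: > 25000 nM
Compound 3 `CCOC(=O)c1cccc(-c2ccc(N(CC)CC)nn2)c1`: > 25000 nM

Compound 2 has no number, only its limit, and the other two compounds also give only limits: the limit of > 25000 nM in this assay, at which 3 of the 3 values shown sit. Compound 4 `CCCCOc1ccc(-c2cccc(C#N)c2)nn1` has butoxy in place of diethylamino on an aromatic carbon. The measured steps, a step that the two limits leave unreadable from compound 1 to compound 2, a step that the two limits leave unreadable from compound 1 to compound 3 and a step that the two limits leave unreadable from compound 2 to compound 3, give no size, and all three leave diethylamino in place. The expectation in this assay therefore rests only on the limit of compound 2 at > 25000 nM, and no large gain in inhibition is expected. The expected step is a step that the limit leaves unreadable from compound 2 to compound 4. Compound 4 is estimated at 30000 nM, within an expected range of 12000 nM to 60000 nM.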

Compound 4, half-maximal inhibitory concentration: > 25000 nM
Compound 4: only a limit was reported (the forecaster's own chance of this, stated with the estimate: 70%); the middle value does not contradict the limit.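

Among the compounds shown here, compound 4, like compound 2, gives only a limit, so no step between compound 2 and compound 4 can be read: the limit of > 25000 nM in this assay, at which 4 of the 4 values shown sit. The compounds shown leave open how strongly any of them inhibits, and whether butoxy and diethylamino differ at all.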